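The source may hold more compounds than are shown below. What is called first, only, known or untested is meant among the compounds shown, and "the series" means these compounds.

Compound 1, `COc1cc2c(cc1N1C[C@@H](C)N(C)[C@@H](C)C1)N(S(=O)(=O)c1cccc(Br)c1)CC2`: 126 nM
Compound 2, `COc1cc2c(cc1N1C[C@@H](C)N(C)[C@@H](C)C1)N(S(=O)(=O)c1ccc3ccccc3c1)CC2`: 39.8 nM

These two compounds share a core and differ only in the group on the sulfonyl sulfur. Among the measured compounds shown here, in a functional assay for agonist activity at growth hormone secretagogue receptor type 1 (Homo sapiens), read by FLIPR (on this read-out lower numbers stand for an effect already at smaller amounts and higher numbers for an effect only at larger amounts of compound), compound 2 gives the lower of the two numbers, and the single measured step, a 3.2-fold lower number from compound 1 to compound 2 (0.50 log units; beyond the scatter), runs toward it.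

Compound 3, `COc1cc2c(cc1N1C[C@@H](C)N[C@@H](C)C1)N(S(=O)(=O)c1ccc3ccccc3c1)CC2`, differs from compound 2 at a different place: hydrogen in place of methyl on an amine nitrogen in a ring. Spoken one bond further out, 3,4,5-trimethylpiperazin-1-yl becomes 3,5-dimethylpiperazin-1-yl. For the measured compounds named here, no measured step touches this ring nitrogen; the only step that has been measured concerns the sulfonyl substituent and therefore says nothing direct about what removing a methyl from the amine nitrogen does. Without a comparable step, the expectation rests on the small size of the change: a single methyl group leaves and a hydrogen takes its place, on a ring that is otherwise unchanged. The step from compound 2 to compound 3 is expected to be a 1.3-fold higher number from compound 2 to compound 3 (0.10 log units; within the scatter). Compound 3 is accordingly estimated at 50 nM in this assay, within a range from 15 nM to 160 nM, pending the measurement.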

Compound 3, half-maximal effective concentration: 0.501 nM
Estimate against measurement, compound 3: 100-fold (2.00 log units) above, outside the stated range (below it).
By their numbers in this assay, from the lowest: compound 3; then compound 2; then compound 1.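

In this assay the amine nitrogen in the six-membered ring proves to be a very sensitive position: with naphthalen-2-yl kept on the sulfonyl sulfur, hydrogen in place of methyl gives a 79-fold lower number from compound 2 to compound 3 (1.90 log units; beyond the scatter) and so brings the lowest number among the compounds shown. This change removes a single heavy atom, yet its step is clearly larger than the earlier change on the sulfonyl sulfur, which gave a 3.2-fold lower number from compound 1 to compound 2 (0.50 log units; beyond the scatter) and offered no hint of what this nitrogen could do. No measurement at hand accounts for so large a step from so small a change.

An ethyl or acetyl group on the same nitrogen would show whether any group larger than hydrogen raises the number, or whether methyl is a special case. From the compounds shown here alone, it also remains open whether hydrogen on this nitrogen brings a step of similar size when 3-bromophenyl sits on the sulfonyl sulfur, and what the methyl groups on the two ring atoms contribute.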